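The source may hold more compounds than are shown below. What is called first, only, known or untested is meant among the compounds shown, and "the series" means these compounds.

Of the compounds shown here, three have numbers so far in an assay for inhibition of Dihydrofolate reductase (Homo sapiens); a lower number here means a less potent compound, a higher number a more potent compound, by a factor of ten per unit of this negative logarithm. Compound 1, `Nc1nc(S)nc2ccc(Sc3ccc4ccccc4c3)cc12`, gives 5.52. Compound 2, `CC(C(=O)Nc1ccc2nc(N)nc(N)c2c1Cl)c1ccccc1`, gives 7.77. Compound 3, `Nc1nc(N)c2cc(Sc3ccc(Cl)c(Cl)c3)ccc2n1`, gives 7.96, the highest of the three numbers; compound 2 lies within the scatter of it, so those two cannot be told apart, while compound 1 lies beyond the scatter. Among the compounds with values here, no single step links any two of these measured compounds, so none of them shows the effect of one change on its own.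

The next compound, compound 4, `Nc1nc(O)c2cc(Sc3ccc(Cl)c(Cl)c3)ccc2n1`, has not yet been measured in this assay. It differs from compound 3 in one place: hydroxy in place of amino on an aromatic carbon. Within the data shown here, nothing among the measured compounds shows this particular exchange, so no measured step gives its size directly. Even so, the step is expected to be large and downward, a number 2.66 log units lower from compound 3 to compound 4 (beyond the scatter). Compound 4 is therefore estimated at 5.3 in this assay, within an expected range from 4.3 to 6.3.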

Compound 4, logarithm of the reciprocal of the active concentration, log(1/C): 6.92
For compound 4 the middle estimate is 1.62 log units below the measured one; measured number outside the range, above it.
By their numbers in this assay, from the lowest: compound 1; then compound 4; then compounds 2 and 3 (each within the scatter of the next).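

In this assay the amino group on this aromatic carbon, next to the ring nitrogen, counts for a real part of the number: hydroxy in place of amino gives a number 1.04 log units lower from compound 3 to compound 4 (beyond the scatter) with the rest of the structure unchanged. The exchange does not wipe out the activity, however, since compound 4 still gives 6.92 in this assay, so amino at this position helps but is not indispensable for this pair. Nothing measured here accounts for the size of this step.

On these data alone, whether a methoxy group, a methyl group or plain hydrogen on this carbon would land nearer to amino or to hydroxy remains open. So does whether the same exchange costs as much when the dichlorophenyl group on the sulfur is replaced by another group.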